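Hydroxy in place of methoxy on a pyrazole-linked phenol

The source may report more compounds than this note shows. Statements on the series, on what has been measured and on what is new or still open speak of the compounds shown alone.

Measured compounds:
Compound 1, `Cc1cc(O)cc(-c2nn(CC#N)cc2-c2ccnc(-c3ccc(Oc4ccccc4)cc3)c2)c1`, 96%
Compound 2, `COc1cc(C)cc(-c2nn(CC#N)cc2-c2ccnc(-c3ccc(N(C)C)cc3)c2)c1`, 92%

In a functional assay on HCT-15 cells (Homo sapiens) for cytotoxicity, read by sulforhodamine B assay, with a stated time of 48 h, tested at 0.01 uM (on this read-out higher numbers stand for a weaker effect at the one concentration tested and lower numbers for a stronger effect), compound 1 gives 96%, and in this assay compound 2 gives 92%. Compound 2 stands within the scatter of compound 1; the two numbers cannot be told apart, and neither compound can be called the more or less active on these readings.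

Compound 3, `Cc1cc(O)cc(-c2nn(CC#N)cc2-c2ccnc(-c3ccc(N(C)C)cc3)c2)c1`, has not been measured. It differs from compound 2 in one place: hydrogen in place of methyl on an oxygen on an aromatic ring. Compound 1 already carries the hydroxy group and its value sits alongside that of compound 2, so the change is expected to bring no step beyond the scatter, a number 1 percentage points higher from compound 2 to compound 3 (within the scatter). For compound 3 the expected result in this assay is 93%, with a range from 82% to 100%.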

Compound 3, a percentage reported as activity, at one concentration (the size of the read-out at that concentration, not a potency): 92%
For compound 3 the middle estimate is 1 percentage points above the measured one, within the range that was stated.
By their numbers in this assay, from the lowest: compounds 2, 3 and 1 (each within the scatter of the next).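

Among these compounds, this pair gives the first direct reading of the oxygen on the aromatic ring with the dimethylamino group held in place: in this assay, hydroxy in place of methoxy gives no change at the digits printed from compound 2 to compound 3 (within the scatter) and so does not separate the two compounds at this one concentration. Compound 3 also allows dimethylamino and phenoxy to be compared with the hydroxy group held in place, and that change gives a number 4 percentage points lower from compound 1 to compound 3 (within the scatter), again without a step that can be told from the scatter. Nothing is available that would explain either reading.

On these data alone, whether an ethoxy group or a longer chain on that oxygen would shift the read-out stays open. So does whether an amine or a carboxylic acid in place of the dimethylamino group would do so, and how any of these changes would read at other concentrations.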